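The source may hold more compounds than are shown below. What is called first, only, known or untested is meant among the compounds shown, and "the series" means these compounds.

Measured compounds in an assay on cells for inhibition of sphingosine kinase 1 (Homo sapiens), read by LC-MS, with stated times of 30 min and 15 min; a lower number here means a stronger inhibitor, a higher number a weaker inhibitor:

compound 1 `Cc1nc2ccc(-c3ccc(CN4CCC[C@@H]4CO)cc3)cc2n1CCC(C)C`, 4 nM
compound 2 `Cc1nc2ccc(-c3ccc(CN4CCCC4)cc3)cc2n1C[C@H]1CCCO1`, "not determined" (no result reported)
compound 3 `O=S(=O)(Cc1cccc(OCc2ccc(CN3CCC[C@@H]3CO)cc2)c1)C1CC1`, 1.7 nM

Compound 3 holds the lower of the two numbers recorded in this assay. Its nearest neighbour on this scale is compound 1, which in this assay gives 4 nM, a higher number and a gap that lies beyond the usual scatter of repeated measurements; compound 3 is therefore the stronger inhibitor of the two. Compound 2 adds no number to this comparison.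

The next compound, compound 4 `Cc1nc(-c2cccc(OCc3ccc(CN4CCC[C@@H]4CO)cc3)c2)no1`, keeps the whole of compound 3 apart from one group. The change is 5-methyl-1,2,4-oxadiazol-3-yl in place of (cyclopropylsulfonyl)methyl on an aromatic carbon. The group that leaves and the group that enters are of nearly the same size and sit at the same place on the same ring.

With no comparable exchange among the measured compounds, the expected step is a small one: the number for compound 4 is estimated to stay within the scatter of that of compound 3, or to rise only slightly, so a 1.8-fold higher number from compound 3 to compound 4 (0.25 log units; within the scatter) is what is expected. Compound 4 is thus estimated at 3 nM in this assay, with a range from 1 nM to 12 nM.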

Compound 4, half-maximal inhibitory concentration: 1.7 nM
For compound 4 the middle estimate is 1.8-fold (0.25 log units) above the measured one; the measured number falls inside the stated range.
By their numbers in this assay, from the lowest: compounds 3 and 4 (each within the scatter of the next); then compound 1.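

In this assay, within the data shown here, replacing (cyclopropylsulfonyl)methyl with 5-methyl-1,2,4-oxadiazol-3-yl on this aromatic carbon gives no change at the digits printed from compound 3 to compound 4 (within the scatter), the first reading in this set of a change made in one place alone. It shows that this position, meta to a large group, tolerates two quite different groups without a measurable shift: one carries sulfur and a three-membered non-aromatic ring of carbon only, the other carries nitrogen and a five-membered aromatic ring with 3 hetero atoms, and neither the loss of the former nor the gain of the latter moves the number. No measured information on these compounds accounts for the two groups reading alike.

Still open, going by these compounds, is how far this tolerance extends, as a single exchange between two groups of nearly the same size cannot show whether a much smaller group such as methyl or a plain hydrogen, or a group such as a carboxylic acid or a primary amine, would keep the number where it stands. On these data alone, it is equally open whether the same exchange would read alike on a different ring position or with the pyrrolidine-type amine end of the molecule altered.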